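Methoxy for Methyl Tried on a Second Core

A few compounds are considered here, and "the series" means these few. Any claim that something is new, unique, unknown or untested is made for them only; others in the source may bear on it.

In a functional assay on HL-60 cells (Homo sapiens) for cytotoxicity, read by luminescence (on this read-out lower numbers stand for stronger inhibition and higher numbers for weaker inhibition), compound 1 `C=C(CC)C(=O)c1ccc(OCC(=O)NCCNS(=O)(=O)c2ccc(C)cc2)c(Cl)c1Cl` gives 2370 nM. Compound 2 `C=C(CC)C(=O)c1ccc(OCC(=O)NCCNS(=O)(=O)c2ccc(OC)cc2)c(Cl)c1Cl` gives 860 nM in this assay. The change between them is methoxy in place of methyl on an aromatic carbon, and it made the step of a 2.8-fold lower number from compound 1 to compound 2 (0.44 log units; beyond the scatter). Compound 3 `C=C(CC)C(=O)c1ccc(OCC(=O)NC2CCN(S(=O)(=O)c3ccc(C)cc3)CC2)c(Cl)c1Cl` carries the same sulfonyl substituent as compound 1, but the difference between the two cores is not broken down here; in this assay compound 3 gives 980 nM. Compound 4 `C=C(CC)C(=O)c1ccc(OCC(=O)NC2CCN(S(=O)(=O)c3ccc(OC)cc3)CC2)c(Cl)c1Cl` is the unmeasured partner of compound 3, differing from it by methoxy in place of methyl on an aromatic carbon, which is the same change as that between compound 1 and compound 2, since the surroundings read alike. Resting on the step of a 2.8-fold lower number from compound 1 to compound 2 (0.44 log units; beyond the scatter) seen on the other core, compound 4 is expected to show a step of similar size, a 2.5-fold lower number from compound 3 to compound 4 (0.39 log units; beyond the scatter), though a single precedent is a thin base. Compound 4 is therefore estimated at 400 nM in this assay, most likely between 150 nM and 1100 nM.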

Compound 4, half-maximal inhibitory concentration: 630 nM
The estimate for compound 4 lay 1.6-fold (0.20 log units) below the measured number; the measured number falls inside the stated range.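

In this assay, the same exchange of methyl for methoxy on the core of compound 3 gives a 1.6-fold lower number from compound 3 to compound 4 (0.19 log units; within the scatter), so on this core the step alone cannot be told from repeat scatter. Set beside the first core, the two steps cannot be told apart: the same change on two cores in this assay, a 2.8-fold lower number (0.44 log units; beyond the scatter) from compound 1 to compound 2 and a 1.6-fold lower number (0.19 log units; within the scatter) from compound 3 to compound 4, 1.8-fold (0.25 log units) apart, within the scatter of two such steps. This fits the change carrying over from one core to the other without a detectable difference, but it does not establish a real gain on the second core, and two pairs make no general rule for the series.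

Going by these compounds, it remains open whether an ethoxy group or an amine on the same aromatic carbon would behave alike. Also open, on these data alone, is how the step runs on a core with a longer chain linking the amide and the sulfonyl group.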